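Swapping One Group on a Shared Core

The compounds below may be only part of what the source reports. "The series", "measured", "known", "first", "only" and "open" are said of these compounds alone.

In a physicochemical assay for lipophilicity, using the shake flask method, in phosphate buffer, measured as octanol-water partition, with a stated time of 30 min, at pH 7.4 (on this read-out lower numbers stand for lower lipophilicity and higher numbers for higher lipophilicity), compound 1 (`CNC(=O)c1ncc(-c2cnc(NCc3c(F)ccc4c3CCO4)c3cn[nH]c(=O)c23)n1C`) gives 2.5 and compound 2 (`CN(c1ccn(C)n1)c1cnc(NCc2c(F)ccc3c2CCO3)c2cn[nH]c(=O)c12`) gives 2.4 on the same scale. These two numbers lie within the scatter of each other, so compound 2 holds no distinct place in this very small set.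

Compound 3 (`Cc1nn(C)cc1-c1cnc(NCc2c(F)ccc3c2CCO3)c2cn[nH]c(=O)c12`) has not yet been measured. It carries 1,3-dimethyl-1H-pyrazol-4-yl in place of methyl(1-methyl-1H-pyrazol-3-yl)amino on an aromatic carbon of the shared core. The exchange in full is 1,3-dimethyl-1H-pyrazol-4-yl in place of methyl(1-methyl-1H-pyrazol-3-yl)amino on an aromatic carbon and nothing else differs.

Among the measured compounds shown here, only one measured step bears on this exchange. The step of a number 0.10 log units lower from compound 1 to compound 2 (within the scatter) came from putting methyl(1-methyl-1H-pyrazol-3-yl)amino in place of 1-methyl-2-(methylcarbamoyl)-1H-imidazol-5-yl on that same aromatic carbon. A single step proves no rule, but it gives no reason to expect a change beyond the scatter in this assay for the new exchange. The estimated step is a number 0.10 log units higher from compound 2 to compound 3 (within the scatter) and it stays within the scatter. For compound 3 the estimated value is 2.5 with an expected range from 2.1 to 2.9 once it is measured.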

Compound 3, distribution coefficient: 2.8
For compound 3 the middle estimate is 0.30 log units below the measured one; low and high end bracket the measured number.
By their numbers in this assay, from the lowest: compounds 2, 1 and 3 (each within the scatter of the next, the first and the last beyond it).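

In this assay, among the compounds shown here, putting 1,3-dimethyl-1H-pyrazol-4-yl in place of methyl(1-methyl-1H-pyrazol-3-yl)amino gives a number 0.40 log units higher from compound 2 to compound 3 (beyond the scatter) and is the only step at this aromatic carbon that lies beyond the usual scatter, so the group held here can shift the read-out. The two groups in this exchange each contain one five-membered aromatic ring with 2 hetero atoms, which shows that sharing that ring type does not guarantee matching numbers; the counts do differ, with 7 heavy atoms and 2 hydrogen-bond acceptors entering against 8 and 3 leaving. The other new comparison, a number 0.30 log units higher from compound 1 to compound 3 (within the scatter), leaves 1-methyl-2-(methylcarbamoyl)-1H-imidazol-5-yl and 1,3-dimethyl-1H-pyrazol-4-yl unseparated, so only compound 2 and compound 3 stand clearly apart.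

No available evidence explains why this exchange moves the number. Still open, from the compounds shown here alone, is where a morpholine, a carboxylic acid or a longer alkyl chain on this aromatic carbon would fall on the scale, and whether this exchange would give a step of similar size on a different core.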